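The source may hold more compounds than are shown below. What is called first, only, known or untested is meant among the compounds shown, and "the series" means these compounds.

Measured compounds in an assay on isolated protein for inhibition of protein deacetylase HDAC6 (Homo sapiens), read by fluorescence, with stated times of 3 h and 60 min; a lower number here means a stronger inhibitor, a higher number a weaker inhibitor:
Compound 1 `O=C(NO)c1ccc(CNc2nccc(-c3cccnc3)n2)cc1` gives 42 nM.
Compound 2 `Nc1cc(-c2ccccc2)ccc1NC(=O)c1ccc(CNc2nccc(-c3cccnc3)n2)cc1` gives only a limit, > 20000 nM.
Compound 3 `COc1ccc(NC(=O)c2ccc(CNc3nccc(-c4cccnc4)n3)cc2)c(N)c1` gives only a limit, > 20000 nM.

Compound 3 thus stands at the limit of this assay, as compound 2 does (the limit of > 20000 nM in this assay, at which 2 of the 3 values shown sit). Within the data shown here, the step of an at least 470-fold higher number from compound 1 to compound 3 (2.67 log units; beyond the scatter) is the one readable step; the step that the two limits leave unreadable from compound 2 to compound 3 cannot be sized. Compound 4 `CC(C)(C)[Si](C)(C)OCc1ccc(NC(=O)c2ccc(CNc3nccc(-c4cccnc4)n3)cc2)c(N)c1` differs from compound 3 by a group of 9 heavy atoms (7 carbon, 1 oxygen, 1 silicon; no ring) in place of a group of 2 heavy atoms (1 carbon, 1 oxygen; no ring), on an aromatic carbon. Both compounds with the 2-amino-phenyl amide sit at the limit, and the change at that ring between compound 2 and compound 3 left the limit untouched; compound 4 keeps that amide. Compound 4 is therefore expected to remain weak, most likely again reported only as a limit, with an estimated 20000 nM (range 5000 nM to 100000 nM), i.e. an expected step of a number no higher from compound 3 to compound 4 (the limit leaves the size open).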

Compound 4, half-maximal inhibitory concentration: > 20000 nM
Compound 4 gave a limit, no number; the forecaster's own chance of this, stated with the estimate: 75%; the middle value lies on the limit itself.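

Among these compounds, compound 4 gives only a limit, so no step to compound 2 or compound 3 can be read: the limit of > 20000 nM in this assay, at which 3 of the 4 values shown sit. On these data alone, whether compound 2, compound 3 and compound 4 differ from one another in strength stays open.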